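Moving the chlorine on the anilino ring: compound 1 to compound 3

The source may hold more compounds than are shown below. What is called first, only, known or untested is meant among the compounds shown, and "the series" means these compounds.

Measured so far:
compound 1 `Clc1ccccc1NCCCOc1ccccc1-c1cc2ccccc2[nH]1`: 6.23 mg/kg
compound 2 `Clc1ccc(NCCCOc2ccc(-c3cc4ccccc4[nH]3)cc2)cc1`: 1.8 mg/kg

In a functional assay on the whole organism (strain albino lyka) with Mus musculus as the target, with stated times of 10 min and 30 min (a higher number here means that more compound is needed for the effect, a lower number that less compound is needed), compound 1 gives 6.23 mg/kg, the highest of the two numbers; in this assay compound 2 gives 1.8 mg/kg, a lower number beyond the usual scatter. Compound 3 `Clc1ccc(NCCCOc2ccccc2-c2cc3ccccc3[nH]2)cc1` differs from compound 1 only by 4-chlorophenyl in place of 2-chlorophenyl on an amine nitrogen. Within the data shown here, no measured pair shows that change on its own, so the size of the step is uncertain; a modest move toward a lower number, or none beyond the scatter, is expected. The step of a 1.6-fold lower number from compound 1 to compound 3 (0.19 log units; within the scatter) is the estimate. For compound 3 the expected value is 4 mg/kg, with a range from 1.8 mg/kg to 9 mg/kg.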

Compound 3, dose for half-maximal effect: 7.23 mg/kg
Compound 3: the middle estimate sits 1.8-fold (0.26 log units) below what was measured, and the stated range covers the measured number.
By their numbers in this assay, from the lowest: compound 2; then compounds 1 and 3 (each within the scatter of the next).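

In this assay putting 4-chlorophenyl in place of 2-chlorophenyl on an amine nitrogen gives a 1.2-fold higher number from compound 1 to compound 3 (0.06 log units; within the scatter) and so this move of the chlorine makes no measurable difference to the dose needed. Among these compounds, this pair isolates that single change for the first time, though it remains only one pair. Nothing available explains the result.

As far as these compounds go, whether an unsubstituted phenyl on the amine nitrogen, or a methoxy group in place of the chlorine, would change the dose remains open. So does the effect of a longer chain.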